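The source may report more compounds than this note shows. Statements on the series, on what has been measured and on what is new or still open speak of the compounds shown alone.

Measured compounds:

Compound 1, `Cc1cc(Br)c(S(C)(=O)=O)cc1C(=O)N=C(N)N` — in this assay 12 nM
Compound 2, `CSc1cc(C)c(C(=O)N=C(N)N)cc1S(C)(=O)=O` — in this assay 6 nM
Compound 3, `Cc1cc(OC(C)C)c(S(C)(=O)=O)cc1C(=O)N=C(N)N` — in this assay 19 nM

All three share one core and differ only in the group on one aromatic carbon. In a functional assay for inhibition of sodium/hydrogen exchanger (Oryctolagus cuniculus) (on this read-out lower numbers stand for stronger inhibition and higher numbers for weaker inhibition), compound 3 gives the highest of the three numbers. Its nearest neighbour is compound 1: the step of a 1.6-fold higher number from compound 1 to compound 3 (0.20 log units; within the scatter) lies within the scatter, so these two cannot be told apart. The step of a 3.2-fold higher number from compound 2 to compound 3 (0.50 log units; beyond the scatter) is beyond the scatter, a modest loss.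

Compound 4, `Cc1cc(N2CCCC(O)C2)c(S(C)(=O)=O)cc1C(=O)N=C(N)N`, has not yet been measured. Compared with compound 3, the change is 3-hydroxypiperidin-1-yl in place of isopropoxy on an aromatic carbon.

The two steps that bear on this change both act at the same aromatic carbon: a 1.6-fold higher number from compound 1 to compound 3 (0.20 log units; within the scatter) and a 3.2-fold higher number from compound 2 to compound 3 (0.50 log units; beyond the scatter). Both were small, so this position has so far tolerated quite different groups with little movement in the numbers. Going by the values given here, no measured compound carries a ring or a hydroxyl at this position, so the present change goes further than any step seen. The expected step of a 1.3-fold higher number from compound 3 to compound 4 (0.12 log units; within the scatter) is therefore small, with direction uncertain. Compound 4 is expected to give about 25 nM in this assay, with a range from 8 nM to 80 nM.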

Compound 4, half-maximal inhibitory concentration: 30 nM
Compound 4: the middle estimate sits 1.2-fold (0.08 log units) below what was measured; the range from low to high includes it.
By their numbers in this assay, from the lowest: compounds 2, 1, 3 and 4 (each within the scatter of the next, the first and the last beyond it).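

In this assay the 3-hydroxypiperidin-1-yl group brings the first ring and the first hydroxyl seen at this position, and the step of a 1.6-fold higher number from compound 3 to compound 4 (0.20 log units; within the scatter) shows that compound 3 and compound 4 cannot be told apart, even though this group is larger than isopropoxy and adds a hydrogen-bond donor. The smaller groups give a different picture, with a 5.0-fold higher number from compound 2 to compound 4 (0.70 log units; beyond the scatter) starting from methylsulfanyl and a 2.5-fold higher number from compound 1 to compound 4 (0.40 log units; beyond the scatter) starting from bromo, so the position accepts the ring and hydroxyl at only a modest cost against those two groups. Nothing available explains these numbers.

The compounds shown cannot say whether the ring or the hydroxyl matters more for the result, and a plain piperidin-1-yl group, without the hydroxyl, would separate the two. Going by these compounds, it also remains open how this position responds to a ring carrying a primary amine or a carboxylic acid in place of the hydroxyl.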